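Iodine for Fluorine on an Indole-Derived Calpain-1 Inhibitor Core

This account rests on a few compounds, and the source may have more. Where it says the series, first, only, none or still open, it means among the compounds named here.

Measured compounds:
compound 1 `O=C(O)/C(S)=C/c1c[nH]c2c(F)cccc12` — 110 nM
compound 2 `O=C(O)/C(S)=C/c1c[nH]c2cc(F)ccc12` — 300 nM
compound 3 `O=C(O)/C(S)=C/c1c[nH]c2cc(I)ccc12` — 300 nM

Three compounds were measured in an assay on isolated protein for inhibition of Calpain-1 catalytic subunit (Sus scrofa); on this read-out lower numbers stand for stronger inhibition and higher numbers for weaker inhibition. Compound 1 gives 110 nM, the lowest of the three numbers, and the gap to compound 2 as well as to compound 3 lies beyond the usual scatter. Compound 1 and compound 2 are built from the same atoms joined differently; how their two cores differ is not broken down here. Compound 2 and compound 3 differ in one place, (iodo in place of fluoro on an aromatic carbon), and that change produced no change at the digits printed from compound 2 to compound 3 (within the scatter).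

Compound 4 `O=C(O)/C(S)=C/c1c[nH]c2c(I)cccc12` has not been measured. It differs from compound 1 by iodo in place of fluoro on an aromatic carbon. Among the measured compounds shown here, this is the same kind of change as the one from compound 2 to compound 3, but its surroundings differ: in compound 1 the carbon that carries the group is ortho to a fused ring and meta to a fused ring, whereas in compound 2 it is meta to a fused ring and para to a fused ring.

For the measured compounds named here, because the only measured example of this change, no change at the digits printed from compound 2 to compound 3 (within the scatter), left the number essentially where it was, compound 4 is expected to stay close to compound 1 in this assay, and the step from compound 1 to compound 4 is estimated as a 1.1-fold higher number from compound 1 to compound 4 (0.04 log units; within the scatter). Going by the values given here, on that basis compound 4 is expected to give about 120 nM, with a likely range from 50 nM to 300 nM; only one prior example supports this, so the range is kept wide.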

Compound 4, half-maximal inhibitory concentration: 220 nM
Estimate against measurement, compound 4: 1.8-fold (0.26 log units) below; measured number inside the range.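

In this assay, putting iodo in place of fluoro on the core of compound 1 gave a 2.0-fold higher number from compound 1 to compound 4 (0.30 log units; within the scatter), so on this core too the step stays within the usual scatter. Set beside the earlier example, the two steps cannot be told apart, and in this small set the change carried from one core to the other without a difference the read-out can resolve: the same change on two cores in this assay, no change at the digits printed (within the scatter) from compound 2 to compound 3 and a 2.0-fold higher number (0.30 log units; within the scatter) from compound 1 to compound 4, 2.0-fold (0.30 log units) apart, within the scatter of two such steps This shows only that two pairs, in which the carbon carrying the group has different surroundings, gave steps that do not separate; it does not show that the two steps are identical, nor that the change would behave the same way on any other core in the series.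

The compounds shown carry only fluoro or iodo on the aromatic carbon, which leaves open how chloro, bromo, a methoxy group or an amine at the same carbon would read in this assay. They also leave open whether iodo in place of fluoro would still give a step within the scatter if an amide took the place of the carboxylic acid.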